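Series notes: carbonyl substituent variation on the shared core

This account rests on a few compounds, and the source may have more. Where it says the series, first, only, none or still open, it means among the compounds named here.

Measured so far:
- compound 1, `Cc1nc(S(C)(=O)=O)ccc1Oc1ncnc(OC2CCN(C(=O)OC(C)F)CC2)c1F`, 68%
- compound 2, `Cc1nc(S(C)(=O)=O)ccc1Oc1ncnc(OC2CCN(C(=O)O[C@@H](C)CF)CC2)c1F`, 84%
- compound 3, `Cc1nc(S(C)(=O)=O)ccc1Oc1ncnc(OC2CCN(C(=O)OC3(C(F)(F)F)CCC3)CC2)c1F`, 82%

In a functional assay on isolated protein for inhibition of Glucose-dependent insulinotropic receptor (Rattus norvegicus), read by HTRF and cAMP accumulation (on this read-out lower numbers stand for smaller maximal responses and higher numbers for larger maximal responses), compound 2 stands highest of the three numbers. Its nearest neighbour is compound 3, with a number 2 percentage points lower from compound 2 to compound 3 (within the scatter), so the two cannot be told apart. Compound 1 lies furthest away, with a number 16 percentage points higher from compound 1 to compound 2 (beyond the scatter).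

Compound 4, `CCC(F)(F)C(=O)N1CCC(Oc2ncnc(Oc3ccc(S(C)(=O)=O)nc3C)c2F)CC1`, has not yet been run. It differs from compound 2 by a group of 5 heavy atoms (3 carbon, 2 fluorine; no ring) in place of a group of 5 heavy atoms (3 carbon, 1 oxygen, 1 fluorine; no ring), on a carbonyl carbon.

Both measured steps that cleared the scatter, a number 16 percentage points higher from compound 1 to compound 2 (beyond the scatter) and a number 14 percentage points higher from compound 1 to compound 3 (beyond the scatter), were exchanges of the group on the oxygen of the carbonyl; the step to compound 4 instead removes that oxygen and places 1,1-difluoropropyl directly on the carbonyl carbon. For the measured compounds named here, no measured pair shows this kind of change, so the measured steps bear only loosely on it. The three measured values sit in a fairly narrow band, and the two larger groups on the carbonyl oxygen gave numbers within the scatter of each other.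

For compound 4 a small downward movement or none beyond the scatter is expected, a number 8 percentage points lower from compound 2 to compound 4 (within the scatter), with the uncertainty widened for the untested type of change. The estimate for compound 4 in this assay is 76%, in the range 60% to 92%.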

Compound 4, largest response reached (reported as efficacy), in percent of the reference or control that the assay uses: 90%
Beside the measured number, compound 4's estimate is 14 percentage points below it; the range from low to high includes it.
By their numbers in this assay, from the lowest: compound 1; then compounds 3, 2 and 4 (each within the scatter of the next).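

In this assay the carbonyl carbon accepts 1,1-difluoropropyl, which has no oxygen attached to that carbon, in place of the oxygen-linked groups: a number 6 percentage points higher from compound 2 to compound 4 (within the scatter) and a number 8 percentage points higher from compound 3 to compound 4 (within the scatter), so neither pair can be told apart. Among these compounds, then, the oxygen-linked form is not required for a maximal response in this range, a point that the earlier exchanges, all made on the oxygen, could not address. For the compounds shown here, the remaining step, a number 22 percentage points higher from compound 1 to compound 4 (beyond the scatter), again leaves compound 1 as the one compound set apart from each of the others, and nothing available offers an explanation for these numbers.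

The compounds shown leave open whether the result depends on the two fluorines of 1,1-difluoropropyl, since the plain propyl group does not appear among them, and whether a longer chain or an amine on the same carbonyl carbon would give a comparable maximal response. They also leave open how the groups compare on any read-out other than largest response.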